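A Chlorine Changes Place on the Benzyl Group

The source may hold more compounds than are shown below. What is called first, only, known or untested is meant among the compounds shown, and "the series" means these compounds.

In a functional assay on SK-MEL-28 cells (Homo sapiens) for inhibition, read by MTT assay, with a stated time of 48 h (on this read-out lower numbers stand for stronger inhibition and higher numbers for weaker inhibition), compound 1 (`COc1ccc(C/N=C2\NC(=O)/C(=C3\CCNC(=O)c4[nH]ccc43)S2)cc1`) gives 12100 nM, and compound 2 (`O=C1N/C(=N\Cc2cccc(Cl)c2)S/C1=C1/CCNC(=O)c2[nH]ccc21`) gives 34700 nM. Compound 2 therefore holds the higher of the two numbers and is the weaker inhibitor of this pair. The next molecule, compound 3 (`O=C1N/C(=N\Cc2ccccc2Cl)S/C1=C1/CCNC(=O)c2[nH]ccc21`), has the same atoms as compound 2, joined differently: 2-chlorophenyl in place of 3-chlorophenyl on a saturated chain carbon bound to a double-bonded nitrogen. In words, 2-chlorophenyl stands in place of 3-chlorophenyl on a saturated chain carbon bound to a double-bonded nitrogen. Among the compounds with values here, only one measured step bears on this change, at the same place in the molecule. There, 3-chlorophenyl replaced 4-methoxyphenyl, giving a 2.9-fold higher number from compound 1 to compound 2 (0.46 log units; beyond the scatter), a modest step. That swap exchanged one group for a different one, whereas the new change keeps the same kind of group and only moves its chlorine. Within the data shown here, no measurement yet shows what such a move does on its own, so a smaller step is expected, with no firm direction. The expected step, a 1.2-fold lower number from compound 2 to compound 3 (0.06 log units; within the scatter), should not exceed the scatter. For compound 3 the estimated value is 30000 nM, with an expected range from 12000 nM to 70000 nM.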

Compound 3, half-maximal inhibitory concentration: > 100000 nM
Compound 3 was reported as a limit; the forecaster's own chance of this, stated with the estimate: 10%; at least 3.3-fold (0.52 log units) between middle value and limit.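

In this assay compound 3 is recorded only as a limit of the assay, not as a number: the limit of > 100000 nM in this assay, at which 1 of the 3 values shown sits. Compound 2 and compound 3 hold the same atoms and differ only in where the chlorine sits on the benzyl group, and the change from 3-chlorophenyl to 2-chlorophenyl gives an at least 2.8-fold higher number from compound 2 to compound 3 (0.45 log units; beyond the scatter), so this read-out responds to the place of the chlorine alone, which the earlier swap of one group for a different one could not show. Measured against the 4-methoxyphenyl group of compound 1, the 2-chlorophenyl group gives an at least 8.2-fold higher number from compound 1 to compound 3 (0.91 log units; beyond the scatter), which leaves compound 1 with the lowest number of the three, with both chlorinated compounds on the weaker side of it.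

Three compounds cannot say whether a plain phenyl group, with no chlorine at all, would fall nearer to compound 1 or to compound 2 in this assay. As far as these compounds go, it also remains open whether a bromine or a methyl group in the chlorine's place would respond to the same move, or how a longer chain between the ring and the double-bonded nitrogen would read.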